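Benzimidazole-nitrogen substituent variation: cyclopentyl in place of isopropyl

The compounds below may be only part of what the source reports. "The series", "measured", "known", "first", "only" and "open" are said of these compounds alone.

Measured compounds in an assay on HEK-293T cells for antagonist activity at vitamin D3 receptor (Homo sapiens), read by a luciferase reporter, with a stated time of 24 h; a lower number here means a stronger inhibitor, a higher number a weaker inhibitor:
compound 1 `CCC(CC)n1c(-c2ccc(OCc3c(-c4c(Cl)cccc4Cl)noc3C(C)C)cc2)nc2ccc(C(=O)O)cc21` gives 5690 nM
compound 2 `CCCn1c(-c2ccc(OCc3c(-c4c(Cl)cccc4Cl)noc3C(C)C)cc2)nc2ccc(C(=O)O)cc21` gives 1400 nM
compound 3 `CC(C)c1onc(-c2c(Cl)cccc2Cl)c1COc1ccc(-c2nc3ccc(C(=O)O)cc3n2C(C)C)cc1` gives 3550 nM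

Compound 3 sits second highest of the three numbers in this assay. Its nearest neighbour is compound 1, and the step of a 1.6-fold lower number from compound 1 to compound 3 (0.20 log units; within the scatter) lies within the scatter. Its furthest neighbour is compound 2, and the step of a 2.5-fold higher number from compound 2 to compound 3 (0.40 log units; beyond the scatter) lies beyond the scatter. The remaining step, a 4.1-fold lower number from compound 1 to compound 2 (0.61 log units; beyond the scatter), is the largest of the set.

Compound 4 `CC(C)c1onc(-c2c(Cl)cccc2Cl)c1COc1ccc(-c2nc3ccc(C(=O)O)cc3n2C2CCCC2)cc1` differs from compound 3 in one place: cyclopentyl in place of isopropyl on an aromatic nitrogen. For the measured compounds named here, the steps that bear on this change are those that vary the same nitrogen substituent, a 1.6-fold lower number from compound 1 to compound 3 (0.20 log units; within the scatter) and a 2.5-fold higher number from compound 2 to compound 3 (0.40 log units; beyond the scatter). The branched pentan-3-yl and isopropyl give numbers within the scatter of each other, while the unbranched propyl gives a lower number. Cyclopentyl is a larger branched group than isopropyl, and the comparison of compound 1 with compound 3 gives no indication of a shift beyond the scatter for a larger branched group. Compound 4 is therefore expected to give 4000 nM in this assay, with a range from 1500 nM to 11000 nM. That estimate means an expected step of a 1.1-fold higher number from compound 3 to compound 4 (0.05 log units; within the scatter), which is not expected to exceed the scatter.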

Compound 4, half-maximal inhibitory concentration: 929 nM
Compound 4: middle estimate off by 4.3-fold (0.63 log units), on the high side; measured number outside the range, below it.
By their numbers in this assay, from the lowest: compounds 4 and 2 (each within the scatter of the next); then compounds 3 and 1 (each within the scatter of the next).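

In this assay, branching on the aromatic nitrogen does not by itself decide the number: cyclopentyl, a ring carrying the same kind of branch point, departs from the open-chain branched groups, with a 3.8-fold lower number from compound 3 to compound 4 (0.58 log units; beyond the scatter) for isopropyl and a 6.1-fold lower number from compound 1 to compound 4 (0.79 log units; beyond the scatter) for pentan-3-yl, both beyond the scatter. Against the unbranched chain, a 1.5-fold lower number from compound 2 to compound 4 (0.18 log units; within the scatter) lies within the scatter, so cyclopentyl and propyl cannot be told apart at this position, and among the four compounds the substituents fall into two groups, cyclopentyl with propyl and isopropyl with pentan-3-yl, rather than following the heavy-atom count, since cyclopentyl and pentan-3-yl differ in ring content and not in carbon count. Nothing available here accounts for the separation between the cyclic and the open-chain branched groups.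

On these data alone, whether this holds for other rings on the same nitrogen, such as cyclobutyl, cyclohexyl or phenyl, remains open. A longer unbranched chain such as butyl, or a chain ending in an amine or a hydroxyl, would show whether the numbers can move further in either direction at this position.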